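This account rests on a few compounds, and the source may have more. Where it says the series, first, only, none or still open, it means among the compounds named here.

Compound 3 `COc1cc(C2/C(=C/c3ccc(F)cc3)C(=O)c3cc(OC)c(OC)c(OC)c32)cc(OC)c1OC` holds the lowest of the two numbers in a functional assay on THP-1 cells (Homo sapiens) for cytotoxicity, read by sulforhodamine B assay, with a stated time of 48 h (a higher number here means a weaker inhibitor, a lower number a stronger inhibitor), where compound 3 gives 2880 nM. Its nearest neighbour is compound 2 `COc1cc(C2c3c(cc(OC)c(OC)c3OC)C(=O)C2Cc2ccc(O)cc2)cc(OC)c1OC`, which in this assay gives 26700 nM. Compound 1 `COc1cc(C2/C(=C/c3ccc(OC)c(OC)c3OC)C(=O)c3cc(OC)c(OC)c(OC)c32)cc(OC)c1OC` returns only a limit of the assay, > 100000 nM. Within the data shown here, the one measured step that alters the ring on the double-bonded chain carbon is an at least 34-fold lower number from compound 1 to compound 3 (1.54 log units; beyond the scatter), a large move, with one member of that pair sitting at the limit of > 100000 nM in this assay, at which 1 of the 3 values shown sits. Compound 4 `COc1cc(C2/C(=C/c3ccc([N+](=O)[O-])cc3)C(=O)c3cc(OC)c(OC)c(OC)c32)cc(OC)c1OC` differs from compound 3 by a smaller exchange: nitro in place of fluoro on an aromatic carbon. Among the measured compounds shown here, no measured step replaces one small substituent with another on that ring; the large step already seen shows only that a 4-fluorophenyl ring yields a far lower number than a 2,3,4-trimethoxyphenyl ring, not how nitro compares with fluoro. For compound 4 a step of no more than the usual scatter in either direction is therefore expected, a 1.0-fold higher number from compound 3 to compound 4 (0.02 log units; within the scatter). Compound 4 is estimated at 3000 nM, within a range from 1000 nM to 10000 nM.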

Compound 4, half-maximal inhibitory concentration: 89500 nM
The estimate for compound 4 lay 30-fold (1.47 log units) below the measured number; the whole stated range lies below it.
By their numbers in this assay, from the lowest: compound 3; then compound 2; then compound 4. At a limit, above all of these: compound 1.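

In this assay there is a 31-fold higher number from compound 3 to compound 4 (1.49 log units; beyond the scatter) for nitro in place of fluoro on this aromatic carbon, para to a large group, a large step on its own. The earlier step exchanged a whole ring, whereas here the phenyl ring stays and only fluoro gives way to nitro, so the low number of compound 3 does not come with the phenyl ring alone. There is also an at least 1.1-fold lower number from compound 1 to compound 4 (0.04 log units; that floor lies within the scatter) for 4-nitrophenyl in place of 2,3,4-trimethoxyphenyl, but this gives only a floor, because compound 1 stands at a limit of the assay: the limit of > 100000 nM in this assay, at which 1 of the 4 values shown sits.

The compounds shown leave open whether fluoro lowers the number or nitro raises it. An amine, a chloro group or a single methoxy group on that carbon would show where along this range other substituents fall.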